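Moving the hydroxyl around the cyclohexyl ring

The source may hold more compounds than are shown below. What is called first, only, known or untested is meant among the compounds shown, and "the series" means these compounds.

Measured so far:
compound 1, `O=C(NC1CCCC1)c1noc(-c2cccc(Cl)c2)c1Br`, 4220 nM
compound 2, `O=C(N[C@H]1CCCC[C@H]1O)c1noc(-c2ccc(C(F)(F)F)cc2)c1Cl`, 65 nM
compound 3, `O=C(NC1CCCC1)c1noc(-c2ccc(C(F)(F)F)cc2)c1F`, 112 nM

Of the compounds shown here, three on a shared core have been measured in a functional assay on CHO cells for antagonist activity at transient receptor potential cation channel subfamily V member 1 (Homo sapiens), read by fluorescence and calcium flux; on this read-out lower numbers stand for stronger inhibition and higher numbers for weaker inhibition. Compound 2 gives the lowest number of the three, 65 nM. Compound 3 stands close to it at 112 nM, a gap that lies within the scatter, so no order between compound 2 and compound 3 can be read from these two values. Compound 1, at 4220 nM, lies well beyond the scatter from compound 2; compound 1 differs from compound 2 in more than one place, so the data show only the two values side by side, not where the gap comes from.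

The next compound, compound 4, `O=C(N[C@H]1CC[C@H](O)CC1)c1noc(-c2ccc(C(F)(F)F)cc2)c1Cl`, keeps everything of compound 2 except the change (4-hydroxycyclohexyl in place of 2-hydroxycyclohexyl on an amide-type nitrogen). Among the measured compounds shown here, no measured pair of compounds shows this change, so its size is open. Compound 3, with a cyclopentyl ring carrying no hydroxyl at all, sits within the scatter of compound 2, and in this assay compound 3 gives 112 nM. This suggests the hydroxyl contributes little that the change to compound 4 would undo, and the step of a 1.8-fold higher number from compound 2 to compound 4 (0.27 log units; within the scatter) is expected to stay small. Compound 4 is therefore estimated at 120 nM, with a range from 40 nM to 400 nM.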

Compound 4, half-maximal inhibitory concentration: 392 nM
Compound 4: middle estimate off by 3.3-fold (0.51 log units), on the low side, and the stated range covers the measured number.
By their numbers in this assay, from the lowest: compounds 2 and 3 (each within the scatter of the next); then compound 4; then compound 1.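

Among the compounds shown here, this is the first pair in the set that differs in one place only, and it shows that this amide-type nitrogen substituent is sensitive to where the hydroxyl sits on the cyclohexyl ring. In this assay, 4-hydroxycyclohexyl in place of 2-hydroxycyclohexyl gives a 6.0-fold higher number from compound 2 to compound 4 (0.78 log units; beyond the scatter), a step beyond the scatter, even though the two groups have the same atoms, the same ring, the same counts of hydrogen-bond donors and acceptors and the same number of defined stereocentres. What lies behind the step is not established by any measurement available here.

This single pair cannot separate the move of the hydroxyl from any contribution of the stereocentres, and it gives no reading of how either compound would compare with a plain cyclohexyl group on the same nitrogen. Also open, as far as these compounds go, is how the number would respond if the hydroxyl on either ring were replaced by a methoxy group or an amine, so the role of the hydroxyl itself remains undefined.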